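A few compounds are considered here, and "the series" means these few. Any claim that something is new, unique, unknown or untested is made for them only; others in the source may bear on it.

Compound 1 `CC(=O)OCCCOC1(c2ccc(Cl)cc2)c2ccccc2C(=O)N1Cc1ccc(Cl)cc1` is one of three compounds whose growth inhibition was measured in a functional assay on HCT-116 cells (Homo sapiens) for inhibition, read by fluorescence, with a stated time of 48 h; on this read-out higher numbers stand for weaker inhibition of growth and lower numbers for stronger inhibition of growth. In this assay compound 1 gives 46000 nM, the second highest of the three numbers. Compound 2 `CC(=O)OCC(C)(C)COC1(c2ccc(Cl)cc2)c2ccccc2C(=O)N1Cc1ccc(Cl)cc1` gives 35000 nM, and compound 3 `O=C1c2ccccc2C(OCCCO)(c2ccc(Cl)cc2)N1Cc1ccccc1` gives 79000 nM; both numbers lie within the usual scatter of compound 1, so none of the three can be called the stronger or weaker inhibitor.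

Compound 4 `CC(=O)OCCCOC1(c2ccc(Cl)cc2)c2ccccc2C(=O)N1Cc1ccccc1` differs from compound 1 in one place: hydrogen in place of chloro on an aromatic carbon.

Among the compounds with values here, the only measured single-place step, a 1.3-fold lower number from compound 1 to compound 2 (0.12 log units; within the scatter), concerns a different part of the molecule, the chain bound to oxygen, and does not reach the chloro group. Within the data shown here, compound 3 also carries a benzyl rather than a 4-chlorobenzyl, but it differs from compound 1 in a second place as well, so its value shows only that a benzyl-bearing compound gave a similar number. With nothing bearing directly on the change, compound 4 is expected to move little, a 1.3-fold higher number from compound 1 to compound 4 (0.12 log units; within the scatter), in this assay. The estimate for compound 4 is 60000 nM, with a range from 25000 nM to 150000 nM.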

Compound 4, concentration for 50% growth inhibition: 50000 nM
The estimate for compound 4 lay 1.2-fold (0.08 log units) above the measured number, and the stated range covers the measured number.
By their numbers in this assay, from the lowest: compounds 2, 1, 4 and 3 (each within the scatter of the next, the first and the last beyond it).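

With hydrogen in place of chloro on an aromatic carbon, the step is a 1.1-fold higher number from compound 1 to compound 4 (0.04 log units; within the scatter), so in this assay the chloro group at this position makes no difference that can be told from the scatter. Within the data shown here, compound 4 also gives a second single-place comparison, which the earlier compounds did not allow: with acetyl in place of hydrogen on an oxygen on a saturated carbon, the step is a 1.6-fold lower number from compound 3 to compound 4 (0.20 log units; within the scatter), so the acetyl and free hydroxyl forms cannot be told apart either. No measurement is available that would explain either result.

As far as these compounds go, it remains open whether a different group on this aromatic carbon, such as a methoxy or an amine, or a carboxylic acid on the chain, would give a number beyond the scatter. All the compounds shown also keep the 4-chlorophenyl group on the core, so the effect of replacing it is unknown.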